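Swapping the five-membered heteroaryl arm of compound 1

A few compounds are considered here, and "the series" means these few. Any claim that something is new, unique, unknown or untested is made for them only; others in the source may bear on it.

In a functional assay on HT-29 cells (Homo sapiens) (a lower number here means a stronger inhibitor of growth, a higher number a weaker inhibitor of growth), two compounds have been measured:
compound 1 `COc1cc(CSc2cc(Cl)c(-c3nnc(-c4ccc(Cl)cc4)s3)cc2S(=O)(=O)NC(=N)NO)cc(OC)c1OC`: 6760 nM
compound 2 `N=C(NO)NS(=O)(=O)c1cc(-c2nnc(-c3ccc(Cl)cc3)s2)c(Cl)cc1SCc1ccccc1`: 1670 nM

Compound 1 stands at the highest of the two numbers, the weaker inhibitor of growth of the pair. Going by the values given here, the only measured step in this set, a 4.0-fold lower number from compound 1 to compound 2 (0.61 log units; beyond the scatter), concerns the group on the saturated chain carbon bound to a sulfur, not the heteroaryl arm.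

Compound 3 `COc1cc(CSc2cc(Cl)c(-c3nc(-c4ccccc4)no3)cc2S(=O)(=O)NC(=N)NO)cc(OC)c1OC` differs from compound 1 at a different place: 3-phenyl-1,2,4-oxadiazol-5-yl in place of 5-(4-chlorophenyl)-1,3,4-thiadiazol-2-yl on an aromatic carbon. Among the compounds with values here, no measured step touches this position, so nothing in the data says how much this assay responds to a change there; the step from compound 1 to compound 2 bears on it only in showing that single changes of this size in the shared core can move the number beyond the scatter.

Within the data shown here, with no step to lean on, the expectation for compound 3 is anchored on compound 1 itself. The step of a 1.1-fold higher number from compound 1 to compound 3 (0.05 log units; within the scatter) is expected to stay within the scatter, with a wide range to allow for either direction. Compound 3 is therefore estimated at 7500 nM, between 2500 nM and 25000 nM.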

Compound 3, concentration for 50% growth inhibition: 7240 nM
Compound 3: middle estimate off by 1.0-fold (0.02 log units), on the high side, within the range that was stated.
By their numbers in this assay, from the lowest: compound 2; then compounds 1 and 3 (each within the scatter of the next).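

In this assay this position now has its first measured step: the change reads a 1.1-fold higher number from compound 1 to compound 3 (0.03 log units; within the scatter) and so shows that, on the core of compound 1, 3-phenyl-1,2,4-oxadiazol-5-yl can stand in place of 5-(4-chlorophenyl)-1,3,4-thiadiazol-2-yl on the aromatic carbon with no change beyond the scatter. The exchange alters the five-membered aromatic ring and removes the chlorine from the outer phenyl ring in a single step, so the result describes the two changes together and cannot assign any share to either one. No measurement offered here gives a reason for this result.

The compounds shown leave open whether 3-phenyl-1,2,4-oxadiazol-5-yl would behave the same way with the unsubstituted phenyl on the sulfur-bound chain carbon, as in compound 2, and whether the two parts of the exchange would each leave the number within the scatter on their own. They also leave open how much this position would tolerate a much smaller group such as a methyl, or a basic one such as an aminomethyl.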